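Replacing a branched alkyl with 1-phenylhexyl on the indole nitrogen

The source may hold more compounds than are shown below. What is called first, only, known or untested is meant among the compounds shown, and "the series" means these compounds.

Measured compounds:
compound 1 `C/C(=C\C(=O)Nc1ccccc1OCCCC(=O)O)c1ccc2c(ccn2C)c1`, 780 nM
compound 2 `CCCC(C(C)C)n1ccc2cc(/C(C)=C/C(=O)Nc3ccccc3OCCCC(=O)O)ccc21`, 7.2 nM
compound 3 `CCCCC(C)n1ccc2cc(/C(C)=C/C(=O)Nc3ccccc3OCCCC(=O)O)ccc21`, 6 nM

In an assay on Prostate gland for inhibition of steroid 5-alpha-reductase (Rattus norvegicus) (on this read-out lower numbers stand for stronger inhibition and higher numbers for weaker inhibition), compound 2 stands second of the three, with compound 3 close by and compound 1 far above it. The change to compound 4 `CCCCCC(c1ccccc1)n1ccc2cc(/C(C)=C/C(=O)Nc3ccccc3OCCCC(=O)O)ccc21` is 1-phenylhexyl in place of 1-isopropylbutyl on an aromatic nitrogen. Within the data shown here, the steps that bear on it are a 110-fold lower number from compound 1 to compound 2 (2.03 log units; beyond the scatter) and a 130-fold lower number from compound 1 to compound 3 (2.11 log units; beyond the scatter), both large gains on moving from methyl to a larger group, while a 1.2-fold lower number from compound 2 to compound 3 (0.08 log units; within the scatter) shows that exchanging one larger group for another changed little. A further exchange of this kind is therefore expected to give no step beyond the scatter, a 1.1-fold higher number from compound 2 to compound 4 (0.05 log units; within the scatter). Compound 4 is estimated at 8 nM, in the range 3 nM to 25 nM.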

Compound 4, half-maximal inhibitory concentration: 25 nM
Compound 4: middle estimate off by 3.1-fold (0.49 log units), on the low side; measured number inside the range.
By their numbers in this assay, from the lowest: compounds 3 and 2 (each within the scatter of the next); then compound 4; then compound 1.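

This position does not treat all larger groups alike: 1-phenylhexyl, with its six-membered aromatic ring, weakens inhibition, with a 3.5-fold higher number from compound 2 to compound 4 (0.54 log units; beyond the scatter) and a 4.2-fold higher number from compound 3 to compound 4 (0.62 log units; beyond the scatter). It still keeps much of the gain over methyl, with a 31-fold lower number from compound 1 to compound 4 (1.49 log units; beyond the scatter). The near match between 1-isopropylbutyl and 1-methylpentyl therefore does not extend to this bigger group, which carries a ring.

Nothing available explains this loss. The compounds shown also leave open whether the phenyl ring or the chain length matters more, which a benzyl group or a plain hexyl chain on the same nitrogen could help separate.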